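The source may report more compounds than this note shows. Statements on the series, on what has been measured and on what is new or still open speak of the compounds shown alone.

Measured so far in an ADME assay on BHK-21 cells (Mesocricetus auratus) for cytotoxicity, read by MTT assay, with a stated time of 96 h; a higher number here means that more compound is tolerated, a lower number that less compound is tolerated:
Compound 1 `COc1ccc(/N=N/N2CCCC2)cc1` reads >= 100000 nM as a limit.
Compound 2 `O=[N+]([O-])c1ccc(/N=N/N2CCCC2)cc1` reads >= 100000 nM as a limit.
Compound 3 `c1ccc(/N=N/N2CCCC2)cc1` reads >= 100000 nM as a limit.

Compound 3 has no exact number in this assay and stands with the other two compounds at one limit (the limit of >= 100000 nM in this assay, at which 3 of the 3 values shown sit). The next compound in the series is compound 4 `Brc1ccc(/N=N/N2CCCC2)cc1` and the change is bromo in place of hydrogen on an aromatic carbon with nothing else altered in the shared core. It puts bromo in place of hydrogen on an aromatic carbon.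

The measured steps that bear on it are a step that the two limits leave unreadable from compound 1 to compound 3 and a step that the two limits leave unreadable from compound 2 to compound 3 together with a step that the two limits leave unreadable from compound 1 to compound 2 and all of them concern a group on an aromatic carbon. None of these steps has a readable size, and methoxy, nitro and hydrogen all end at the same limit. No step beyond the scatter is therefore expected in this assay and no direction can be given. This expectation rests on compound 3 with its limit of >= 100000 nM as the starting point. The estimated size of a number no higher from compound 3 to compound 4 (the limit leaves the size open) is expected to stay within the scatter. The estimate for compound 4 is 100000 nM with an expected range from 40000 nM to 150000 nM and a report of a limit alone is the likeliest outcome.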

Compound 4, half-maximal cytotoxic concentration: > 100000 nM
Compound 4 was reported as a limit; the forecaster's own chance of this, stated with the estimate: 75%; the middle value lies on the limit itself.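

In this assay compound 4 reads > 100000 nM, which is a limit. For the compounds shown here, compounds 1, 2 and 3 are also reported only as limits, so no step from any of them to compound 4 can be read. The compounds shown leave open the exact half-maximal cytotoxic concentration of all four compounds and whether these aromatic-carbon groups differ at all.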